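The source may report more compounds than this note shows. Statements on the series, on what has been measured and on what is new or still open speak of the compounds shown alone.

Three compounds share one core. Compound 1 `CC(O)Cn1nnnc1-c1ccccc1-c1ccc(CN2C(=O)[C@H](NC(=O)CC(C)(C)N)CCc3ccccc32)cc1` gives 0.05 uM in a functional assay (Pituitary gland cell) with Rattus norvegicus as the target; a higher number here means that more compound is needed for the effect, a lower number that less compound is needed. Compound 2 `CC(C)(N)CC(=O)N[C@@H]1CCc2ccccc2N(Cc2ccc(-c3ccccc3C(=O)O)cc2)C1=O` gives 3 uM in this assay, and compound 3 `CC(C)(N)CC(=O)N[C@@H]1CCc2ccccc2N(Cc2ccc(-c3ccccc3C#N)cc2)C1=O` gives 5 uM in this assay, the highest of the three numbers, although compound 2 and compound 3 lie within the scatter of each other, as a 1.7-fold higher number from compound 2 to compound 3 (0.22 log units; within the scatter) shows. Compound 4 `Cn1nnc(-c2ccccc2-c2ccc(CN3C(=O)[C@H](NC(=O)CC(C)(C)N)CCc4ccccc43)cc2)n1` carries 2-methyl-2H-tetrazol-5-yl in place of cyano on an aromatic carbon. The step that bears most on this change is a 100-fold higher number from compound 1 to compound 3 (2.00 log units; beyond the scatter), since compound 1 holds a tetrazole ring at the same place; a 60-fold higher number from compound 1 to compound 2 (1.78 log units; beyond the scatter) points the same way. A large step toward a lower number is therefore expected, a 50-fold lower number from compound 3 to compound 4 (1.70 log units; beyond the scatter), allowing for the different substituent on the tetrazole of compound 1. Compound 4 is estimated at 0.1 uM, within 0.02 uM to 0.6 uM.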

Compound 4, concentration for half-maximal effect: 0.3 uM
Compound 4: the middle estimate sits 3.0-fold (0.48 log units) below what was measured; low and high end bracket the measured number.
By their numbers in this assay, from the lowest: compound 1; then compound 4; then compounds 2 and 3 (each within the scatter of the next).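

A tetrazole does not need the hydroxypropyl chain of compound 1 to beat the nitrile or the carboxylic acid: this assay gives a 17-fold lower number from compound 3 to compound 4 (1.22 log units; beyond the scatter) and a 10-fold lower number from compound 2 to compound 4 (1.00 log units; beyond the scatter). The group on the tetrazole still matters, as a 6.0-fold higher number from compound 1 to compound 4 (0.78 log units; beyond the scatter) shows that 2-methyl-2H-tetrazol-5-yl does not fully match 1-(2-hydroxypropyl)-1H-tetrazol-5-yl. No measurement here explains these steps. On these data alone, compounds 1 and 4 differ in both the chain and its place on the tetrazole, so the contribution of each remains open. A 1-methyl-1H-tetrazol-5-yl group or an unsubstituted tetrazole would help separate them.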